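A few compounds are considered here, and "the series" means these few. Any claim that something is new, unique, unknown or untested is made for them only; others in the source may bear on it.

Working notes on the thiosemicarbazone series. Compound 1 `CC1=CC[C@H](C(C)(C)NC(=S)N/N=C/c2ccccc2)CC1` carries an unsubstituted aromatic ring; in an ADME assay on Vero cells (Chlorocebus sabaeus) for inhibition, read by sulforhodamine B assay, with a stated time of 48 h (a lower number here means a stronger inhibitor of growth, a higher number a weaker inhibitor of growth), compound 1 gives a limit of the assay, > 100000 nM. Compound 2 `CC1=CC[C@H](C(C)(C)NC(=S)N/N=C/c2cccc(Cl)c2)CC1` carries chloro on that ring; in this assay compound 2 likewise gives only a limit, > 100000 nM. For the measured compounds named here, the one measured step, a step that the two limits leave unreadable from compound 1 to compound 2, therefore cannot be read for size, both values sitting at the limit of > 100000 nM in this assay, at which 2 of the 2 values shown sit. Compound 2 thus stands at the upper limit of this assay, with no number of its own.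

Compound 3 `CC1=CC[C@H](C(C)(C)NC(=S)N/N=C/c2cccc([N+](=O)[O-])c2)CC1` differs from compound 2 by nitro in place of chloro on an aromatic carbon. Going by the values given here, the only step that bears on a change at this aromatic carbon is the unreadable one from compound 1 to compound 2, so no direction is indicated. The expected step that the limit leaves unreadable from compound 2 to compound 3 is accordingly none beyond the scatter, in either direction. Compound 3 is estimated at 150000 nM, range 50000 nM to 500000 nM, most likely again reported as a limit.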

Compound 3, concentration for total growth inhibition: > 100000 nM
Compound 3: no number, only a limit; the forecaster's own chance of this, stated with the estimate: 80%; the middle value does not contradict the limit.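

For the compounds shown here, compound 3 gives only a limit in this assay, so no step among compound 1, compound 2 and compound 3 can be read for size: the limit of > 100000 nM in this assay, at which 3 of the 3 values shown sit. The compounds shown leave open whether chloro or nitro on the aromatic ring changes growth inhibition at all.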